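A few compounds are considered here, and "the series" means these few. Any claim that something is new, unique, unknown or untested is made for them only; others in the source may bear on it.

For the measured compounds named here, compound 3 `Cc1ccc(NC(=O)Nc2ccc(Oc3ccc(-c4ncc[nH]4)cc3)cc2)cc1` stands highest of the three measured members in a functional assay on MDA-MB-231 cells (Homo sapiens) for inhibition, read by MTT assay and WST assay, with a stated time of 72 h, tested at 10 uM (a higher number here means more inhibition of growth at the concentration tested, a lower number less inhibition of growth), where compound 3 gives 49.3%. Compound 1 `O=C(Nc1ccccc1)Nc1ccc(Oc2ccc(-c3ncc[nH]3)cc2)cc1` gives 11.4%, and compound 2 `O=C(Nc1ccc(Oc2ccc(-c3ncc[nH]3)cc2)cc1)Nc1ccc(Cl)c([N+](=O)[O-])c1` gives 3.36%; these two lie within the scatter of each other, a number 8 percentage points lower from compound 1 to compound 2 (within the scatter). The methyl is what sets compound 3 apart: a number 37.9 percentage points higher from compound 1 to compound 3 (beyond the scatter), and a number 45.9 percentage points higher from compound 2 to compound 3 (beyond the scatter).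

Compound 4 `O=C(Nc1ccc(Oc2ccc(-c3ncc[nH]3)cc2)cc1)Nc1ccc(F)c(Cl)c1` is the next member, differing from compound 3 by 3-chloro-4-fluorophenyl in place of 4-methylphenyl on an amide-type nitrogen. Going by the values given here, two measured steps bear on this change. The step from compound 1 to compound 3 is the measured size of putting the methyl in; taking it out again would be expected to undo most of that step. The step from compound 2 to compound 3 shows that a halogenated, substituted phenyl on the same nitrogen sat lower still, though the step from compound 1 to compound 2 stayed within the scatter, so no separate effect of the halogens is shown. Compound 4 is therefore expected to drop by a step of a number 34.3 percentage points lower from compound 3 to compound 4 (beyond the scatter). The estimate for compound 4 in this assay is 15%, with a range from 3% to 35%.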

Compound 4, percent growth inhibition at one concentration: 4.2%
Compound 4: the middle estimate sits 10.8 percentage points above what was measured; the range from low to high includes it.
By their numbers in this assay, from the lowest: compounds 2, 4 and 1 (each within the scatter of the next); then compound 3.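

In this assay the change to 3-chloro-4-fluorophenyl on the amide-type nitrogen gives a number 45.1 percentage points lower from compound 3 to compound 4 (beyond the scatter) and so removes what the methyl had gained, which shows that a phenyl carrying halogens in place of 4-methylphenyl does not keep compound 3's level. The other two steps, a number 0.8 percentage points higher from compound 2 to compound 4 (within the scatter) and a number 7.2 percentage points lower from compound 1 to compound 4 (within the scatter), both stay within the scatter, so compound 1, compound 2 and compound 4 form one low group, and among the four aryl groups on this nitrogen only 4-methylphenyl stands apart. There is no evidence on why the two groups differ so widely at this nitrogen.

The compounds shown leave open whether the high level belongs to the methyl itself or would also appear with 4-ethylphenyl or 4-methoxyphenyl, and whether a single halogen, as in 4-fluorophenyl or 4-chlorophenyl, would sit with the low group. A 3-chloro-4-methylphenyl group, carrying the methyl and a chlorine together, would also show whether the methyl's gain survives with a halogen on the same ring.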